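Trimming the Trimethylphenyl Sulfonyl Group of Compound 3

The compounds below may be only part of what the source reports. "The series", "measured", "known", "first", "only" and "open" are said of these compounds alone.

Measured compounds:
compound 1 `Cc1ccc(N2CCN(c3ccc(C(=O)/C=C/c4ccccc4)cc3)CC2)cc1`: 2.85%
compound 2 `O=C(/C=C/c1ccccc1)c1ccc(N2CCN(c3ccccc3)CC2)cc1`: 3.71%
compound 3 `Cc1cc(C)c(S(=O)(=O)N2CCN(c3ccc(C(=O)/C=C/c4ccccc4)cc3)CC2)c(C)c1`: 55.5%

In a functional assay on the whole organism (strain Kunming) for inhibition, with Mus musculus as the target, with a stated time of 1 h, at a dose of 40 mg/kg by the oral route (a lower number here means less inhibition, a higher number more inhibition at the dose given (going by the name of the read-out)), compound 3 stands highest of the three numbers, beyond the scatter from both compound 2 and compound 1. Compound 4 `O=C(/C=C/c1ccccc1)c1ccc(N2CCN(S(=O)(=O)c3ccccc3)CC2)cc1` differs from compound 3 by phenyl in place of 2,4,6-trimethylphenyl on a sulfonyl sulfur. Within the data shown here, no measured step removes methyl groups from a sulfonyl aryl; the only measured step, a number 0.9 percentage points higher from compound 1 to compound 2 (within the scatter), concerns a single methyl on the aryl piperazine and was within the scatter. Since that step bears only loosely on the change, compound 4 is expected to keep much of the inhibition of compound 3, with the estimated step of a number 10.5 percentage points lower from compound 3 to compound 4 (beyond the scatter) carrying wide uncertainty. For compound 4 the estimate is 45%, between 20% and 65%.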

Compound 4, a percentage reported as inhibition, in the whole organism at one dose (the size of the read-out at that dose, not a potency): 30%
For compound 4 the middle estimate is 15 percentage points above the measured one, within the range that was stated.
By their numbers in this assay, from the lowest: compounds 1 and 2 (each within the scatter of the next); then compound 4; then compound 3.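

In this assay phenyl in place of 2,4,6-trimethylphenyl on the sulfonyl sulfur gives a number 25.5 percentage points lower from compound 3 to compound 4 (beyond the scatter) and so shows that the methyl groups on this ring count. Even without them, phenylsulfonyl in place of phenyl on the amine nitrogen in a ring gives a number 26.3 percentage points higher from compound 2 to compound 4 (beyond the scatter) and phenylsulfonyl in place of 4-methylphenyl there gives a number 27.2 percentage points higher from compound 1 to compound 4 (beyond the scatter) as well. Nothing available explains these steps.

From the compounds shown here alone, whether a single methyl group on the sulfonyl phenyl would restore part of the loss stays open. So does the effect of a methoxy group, a chlorine or a carboxylic acid on that ring.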